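Dichloro to monochloro core: removing the chloro between ring nitrogens

The source may hold more compounds than are shown below. What is called first, only, known or untested is meant among the compounds shown, and "the series" means these compounds.

Compound 2 `ClCc1ccccc1Cn1cnc2c(Cl)nc(Cl)nc21` stands lowest of the two numbers measured in a functional assay on DU-145 cells (Homo sapiens) for cytotoxicity, read by sulforhodamine B assay, with a stated time of 48 h (a higher number here means a weaker inhibitor of growth, a lower number a stronger inhibitor of growth), where compound 2 gives 130 nM. Its nearest neighbour is compound 1 `ClCc1ccc(Cn2cnc3c(Cl)ncnc32)cc1`; in this assay compound 1 gives 1310 nM, a gap that lies beyond the scatter. Going by the values given here, compound 1 and compound 2 differ in more than one place, so the two values together show only that the pair spans a wide range.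

Compound 3 `ClCc1ccccc1Cn1cnc2c(Cl)ncnc21` is the next member. It differs from compound 2 by hydrogen in place of chloro on an aromatic carbon. Among the compounds with values here, no matched pair with this single change exists among the measured compounds, so the size of the step is not known from the data. The core of compound 3 is that of compound 1, which gave 1310 nM, and the higher number of compound 1 points toward a weaker inhibitor of growth.

For compound 3 a moderate rise is expected, a step of a 4.6-fold higher number from compound 2 to compound 3 (0.66 log units; beyond the scatter), beyond the scatter but short of the gap to compound 1. The estimate for compound 3 is 600 nM, with a range of 150 nM to 2500 nM.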

Compound 3, concentration for 50% growth inhibition: 5620 nM
Beside the measured number, compound 3's estimate is 9.4-fold (0.97 log units) below it; the measured number lies above the stated range.
By their numbers in this assay, from the lowest: compound 2; then compound 1; then compound 3.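

In this assay, going by these compounds alone, this is the first comparison that differs in one place only: chloro gives way to hydrogen on the aromatic carbon between two ring nitrogen atoms, a change that gives a 43-fold higher number from compound 2 to compound 3 (1.64 log units; beyond the scatter). The step belongs to this position and this change alone, whereas the gap between compound 1 and compound 2 could not be assigned to any single place, and with the other chloro group and the rest of the structure unchanged, the chloro at this position counts for a large part of the growth inhibition seen with compound 2. Nothing available accounts for the size of this step.

The compounds shown compare only chloro and hydrogen at this position, so it remains open whether an amine, a methoxy group or a nitrile there would keep a number near that of compound 2. Also open is whether the step keeps its size when the chloromethyl group sits as it does in compound 1, since the pair shown covers only the arrangement of compound 2 and compound 3.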